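The source may report more compounds than this note shows. Statements on the series, on what has been measured and on what is new or still open speak of the compounds shown alone.

Of the compounds shown here, three that share one core have been measured so far. In a functional assay on MCF7 cells (Homo sapiens) for cytotoxicity, read by MTT assay and propidium iodide staining, with a stated time of 24 h (on this read-out lower numbers stand for stronger inhibition and higher numbers for weaker inhibition), compound 1 (`Cc1ccc(-c2nnc(SCC(=O)c3ccccc3)o2)c(O)c1`) gives 150 nM, compound 2 (`CN(C)c1ccc(-c2nnc(SCC(=O)c3ccccc3)o2)cc1`) gives 210 nM, and compound 3 (`O=C(CSc1nnc(-c2ccncc2)o1)c1ccccc1`) gives 370 nM. Compound 3 lies within the usual scatter of compound 2, so these two cannot be told apart on these numbers. Its gap to compound 1 goes beyond the scatter, and compound 3 has the higher number, which stands for weaker inhibition.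

The next compound is compound 4 (`Nc1cc(-c2nnc(SCC(=O)c3ccccc3)o2)ccn1`). Compared with compound 3, it carries one change, next to the ring nitrogen, turning pyridin-4-yl into 2-aminopyridin-4-yl: amino in place of hydrogen on an aromatic carbon.

Among the measured compounds shown here, no two measured compounds differ in only one place, so the data give no direct measure of what such a change does. For the measured compounds named here, the only guide is the overall spread, from compound 1 at 150 nM to compound 3 at 370 nM, across compounds that differ in the group attached to the core. On that basis, no step beyond the scatter is expected in this assay. The expected change, a 1.3-fold lower number from compound 3 to compound 4 (0.11 log units; within the scatter), is therefore small and its direction is uncertain. For compound 4 the estimated value is 290 nM, with an expected range from 120 nM to 700 nM.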

Compound 4, half-maximal inhibitory concentration: 140 nM
Compound 4: the middle estimate sits 2.1-fold (0.32 log units) above what was measured, within the range that was stated.
By their numbers in this assay, from the lowest: compounds 4, 1, 2 and 3 (each within the scatter of the next, the first and the last beyond it).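

Among the compounds shown here, compound 3 and compound 4 are the first pair here that differ in only one place, so this assay now gives a direct reading of a single change. Putting amino in place of hydrogen on an aromatic carbon, next to the ring nitrogen, brings a 2.6-fold lower number from compound 3 to compound 4 (0.42 log units; beyond the scatter) and so moves the number toward stronger inhibition by more than repeat measurements would normally scatter. The earlier compounds could not show this, as they differ in the whole group attached to the shared core, whereas this step shows that one small group at this position of the pyridin-4-yl ring can shift the read-out, though nothing available explains how.

The compounds shown leave open whether this shift belongs to amino in particular or would also come with another group in the same place, such as methoxy, fluorine or an acetamido group. They also leave open whether amino would give a similar step on another carbon of this ring, or on the phenyl ring of the phenacyl part that all four compounds share.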